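This account rests on a few compounds, and the source may have more. Where it says the series, first, only, none or still open, it means among the compounds named here.

Measured compounds in a functional assay on the whole organism for inhibition, with Digitaria ciliaris as the target, with a stated time of 72 h, tested at 100 mg/L; on this read-out lower numbers stand for less inhibition of growth and higher numbers for more inhibition of growth at the one concentration tested:
- compound 1 `COc1cc(Cl)nc2n/c(=N/C(=O)c3c(-c4ccc(Cl)cc4Cl)noc3C)sn12`; compound 1 gives 72.8%
- compound 2 `COc1cc(C)nc(NC(=S)NC(=O)c2c(-c3ccc(Cl)cc3Cl)noc2C)n1`; compound 2 gives 60.2%
- compound 3 `COc1cc(SC)nc2n/c(=N/C(=O)c3c(-c4ccc(Cl)cc4Cl)noc3C)sn12`; compound 3 gives 79.6%

Compound 2 stands lowest of the three numbers. Its nearest neighbour is compound 1, higher by a margin beyond the scatter, and compound 3 lies further off, also beyond the scatter. Among the compounds with values here, the only measured single-point step in the set, a number 6.8 percentage points higher from compound 1 to compound 3 (within the scatter), concerns a different exchange on the core shared by compound 1 and compound 3, not the core of compound 2, so it does not bear on the step considered here.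

Compound 4 `Cc1cc(C)nc(NC(=S)NC(=O)c2c(-c3ccc(Cl)cc3Cl)noc2C)n1` differs from compound 2 by methyl in place of methoxy on an aromatic carbon. Cut one bond further out, the change reads 4-methoxy-6-methylpyrimidin-2-yl to 4,6-dimethylpyrimidin-2-yl. Within the data shown here, no measured pair shows this exchange, and no direction is supported by the data. The expectation is therefore a step that does not exceed the scatter, a number 2.2 percentage points lower from compound 2 to compound 4 (within the scatter), in this assay. Compound 4 is estimated at 58%, with an expected range from 40% to 76%.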

Compound 4, percent growth inhibition at one concentration: 61.4%
The estimate for compound 4 lay 3.4 percentage points below the measured number, and the stated range covers the measured number.
By their numbers in this assay, from the lowest: compounds 2 and 4 (each within the scatter of the next); then compounds 1 and 3 (each within the scatter of the next).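

In this assay, within the data shown here, methyl in place of methoxy on this aromatic carbon gives a number 1.2 percentage points higher from compound 2 to compound 4 (within the scatter) and provides the first measured exchange at this position. Going from 4-methoxy-6-methylpyrimidin-2-yl to 4,6-dimethylpyrimidin-2-yl removes the methoxy oxygen, and the step stays within the scatter at the one concentration tested, so on the core of compound 2 these two groups cannot be told apart by this read-out. No available measurement bears on the reason for this step.

As far as these compounds go, whether this position stays equally undiscriminating with an amine or an ethoxy chain remains open. Also open, from the compounds shown here alone, is whether the same exchange would read alike on the core shared by compound 1 and compound 3, where the methoxy stands on a different ring system.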